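The source may report more compounds than this note shows. Statements on the series, on what has been measured and on what is new or still open speak of the compounds shown alone.

Measured so far:
- compound 1 `O=C1/C(=C/c2ccccc2)CCC/C1=C\c1ccc([N+](=O)[O-])cc1`: 5.08 in a physicochemical assay for lipophilicity; a higher number here means a more lipophilic compound, a lower number a more polar compound
- compound 2 `Cc1ccc(/C=C2\CCC/C(=C\c3cccc([N+](=O)[O-])c3)C2=O)cc1`: 5.06 in this assay
- compound 3 `O=C1/C(=C/c2ccc(Cl)cc2)CCC/C1=C\c1ccccc1[N+](=O)[O-]`: 4.86 in this assay

Compound 2 sits among three numbers that all lie within the usual scatter of one another, so none of the three can be called more or less lipophilic than another. Compound 4 `O=C1/C(=C/c2ccc(Cl)cc2)CCC/C1=C\c1cccc([N+](=O)[O-])c1` has not yet been measured in this assay. It differs from compound 2 in one place: chloro in place of methyl on an aromatic carbon. Swapping one heavy atom for another of the same count, with no change in ring, donors, acceptors or charge, is a small alteration, and no shift beyond the scatter is expected from it. The step from compound 2 to compound 4 is estimated at a number 0.14 log units higher from compound 2 to compound 4 (within the scatter), a slight rise at most. For compound 4 the expected value in this assay is 5.2, in a range of 4.9 to 5.5.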

Compound 4, partition coefficient: 5.06
Compound 4: the middle estimate sits 0.14 log units above what was measured; measured number inside the range.
By their numbers in this assay, from the lowest: compounds 3, 2, 4 and 1 (each within the scatter of the next).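

In this assay, putting chloro in place of methyl on this aromatic carbon, para to a large group, gives no change at the digits printed from compound 2 to compound 4 (within the scatter). This is the first pair shown that differs in one place, so the change from 4-methylphenyl to 4-chlorophenyl can be read directly, and the two groups cannot be told apart here. Nothing measured here offers a reason for this result.

The compounds shown leave open whether an amine, a carboxylic acid or a longer chain at this same carbon would also stay within the scatter. This single pair also cannot say whether methyl and chloro would match on other versions of the core.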